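A few compounds are considered here, and "the series" means these few. Any claim that something is new, unique, unknown or untested is made for them only; others in the source may bear on it.

Of the compounds shown here, three have so far been tested in an ADME assay on L6 cells (Rattus norvegicus) for cytotoxicity, read by resazurin assay, with a stated time of 72 h; a higher number here means a weaker inhibitor, a lower number a stronger inhibitor. Compound 1 `N=C(N)c1ccc(COc2ccc(C(=N)N)cc2Cl)cc1` gives 3200000 nM. Compound 2 `N=C(N)c1ccc(COc2c(Cl)cc(C(=N)N)cc2Cl)cc1` gives 28500000 nM; it carries one added chloro group, the change being (chloro in place of hydrogen on an aromatic carbon), and the measured step is an 8.9-fold higher number from compound 1 to compound 2 (0.95 log units; beyond the scatter). Compound 3 `N=C(N)c1cccc(COc2ccc(C(=N)N)cc2Cl)c1` gives 13900000 nM; how the core of compound 3 differs from the core of compound 1 is not broken down here.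

Compound 4 `N=C(N)c1cccc(COc2c(Cl)cc(C(=N)N)cc2Cl)c1` has not yet been measured in this assay. It differs from compound 3 by chloro in place of hydrogen on an aromatic carbon, the same change that turns compound 1 into compound 2, at a place described in the same words. If that step carries over to the new core, compound 4 is expected to move by a 7.2-fold higher number from compound 3 to compound 4 (0.86 log units; beyond the scatter), an expectation that rests on compound 3 at 13900000 nM together with the step of an 8.9-fold higher number from compound 1 to compound 2 (0.95 log units; beyond the scatter). One earlier example is thin ground, so the range is kept wide. Compound 4 is therefore estimated at 100000000 nM, between 35000000 nM and 300000000 nM.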

Compound 4, half-maximal inhibitory concentration: 570000 nM
Beside the measured number, compound 4's estimate is 180-fold (2.24 log units) above it; the measured number lies below the stated range.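

In this assay, the added chloro group gives a 24-fold lower number from compound 3 to compound 4 (1.39 log units; beyond the scatter), which is opposite in direction to the earlier step with the same change. In this series, then, the step measured on one core cannot simply be carried over to the other, as both its size and its direction differ between the two cores: the same change on two cores in this assay, an 8.9-fold higher number (0.95 log units; beyond the scatter) from compound 1 to compound 2 and a 24-fold lower number (1.39 log units; beyond the scatter) from compound 3 to compound 4, 220-fold (2.34 log units) apart, beyond the scatter of two such steps

This shows only that the outcome of the change depends on the core it is made on; it does not show why, and two pairs cannot predict which way the step would go on a third core. On these data alone, whether a different group at the same place, such as bromo or methyl, would also move in opposite directions on these two cores remains open. Also open, as far as these compounds go, is how an amine or a carboxylic acid at that place would behave on each core.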